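Swapping the aryl ketone arm for a methylthiophene

A few compounds are considered here, and "the series" means these few. Any claim that something is new, unique, unknown or untested is made for them only; others in the source may bear on it.

Three measured compounds share one core and differ only at a saturated chain carbon bound to an aromatic carbon. Compound 1 `CCc1ccc(C(=O)c2ccn(-c3ccc4c(c3)B(O)OC4)c2)cc1` carries a methyl there; in an ADME assay on L929 cells (Mus musculus) for cytotoxicity, read by resazurin assay, with a stated time of 72 h (on this read-out lower numbers stand for stronger inhibition and higher numbers for weaker inhibition), compound 1 gives only a limit, > 10 ug/mL. Compound 2 `O=C(c1ccc(CO)cc1)c1ccn(-c2ccc3c(c2)B(O)OC3)c1` carries hydroxy in place of methyl; in this assay compound 2 gives 9.31 ug/mL. Compound 3 `NCc1ccc(C(=O)c2ccn(-c3ccc4c(c3)B(O)OC4)c2)cc1` carries amino in place of methyl; in this assay compound 3 gives only a limit, > 10 ug/mL. Compound 3 thus stands at the limit of > 10 ug/mL in this assay, at which 2 of the 3 values shown sit. The measured steps are an at least 1.0-fold lower number from compound 1 to compound 2 (0.03 log units; that floor lies within the scatter), an at least 1.0-fold higher number from compound 2 to compound 3 (0.03 log units; that floor lies within the scatter) and a step that the two limits leave unreadable from compound 1 to compound 3; none of them leaves the scatter.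

Compound 4 `Cc1ccsc1C(=O)c1ccn(-c2ccc3c(c2)B(O)OC3)c1` differs from compound 3 at another place: 3-methylthiophen-2-yl in place of 4-(aminomethyl)phenyl on a carbonyl carbon. Within the data shown here, no measured step alters the group on the carbonyl carbon, so none bears directly on this change, and those that exist stayed within the scatter. The author therefore expects a step that the limit leaves unreadable from compound 3 to compound 4, nothing beyond the scatter. Compound 4 is estimated at 12 ug/mL, with a range from 5 ug/mL to 30 ug/mL.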

Compound 4, half-maximal inhibitory concentration: > 10 ug/mL
Compound 4: no number, only a limit (the forecaster's own chance of this, stated with the estimate: 60%); the middle value lies beyond the limit too.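

Among these compounds, the replacement on the carbonyl carbon is the first change at this place, and it swaps a six-membered aromatic ring of carbon only for a five-membered aromatic ring with 1 hetero atom. In this assay compound 4 gives only a limit, > 10 ug/mL. The one step that can be read is an at least 1.0-fold higher number from compound 2 to compound 4 (0.03 log units; that floor lies within the scatter), so this change shows no effect beyond the scatter, the steps to compound 4 from compound 1 and compound 3 cannot be read, and the series now gathers at one value: the limit of > 10 ug/mL in this assay, at which 3 of the 4 values shown sit.

The compounds shown leave open how far beyond the limit compound 1, compound 3 and compound 4 actually lie. They also leave open whether a carboxylic acid or a longer chain on the carbonyl carbon would change the read-out.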